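A few compounds are considered here, and "the series" means these few. Any claim that something is new, unique, unknown or untested is made for them only; others in the source may bear on it.

Going by the values given here, compound 1 `CCCCCCCCCCCCCCC1(C(=O)OCC(O)CO)CO1` is one of two compounds measured in a functional assay on the whole organism with Rattus norvegicus as the target, in the glucose tolerance test; on this read-out lower numbers stand for an effect already at smaller amounts and higher numbers for an effect only at larger amounts of compound. There compound 1 gives 5 mg/kg, and compound 2 `CCCCCCCCCCCCCCCCCCCCCCC1(C(=O)OC)CO1` gives 10 mg/kg, the two numbers lying within the usual scatter of one another. Compound 3 `CCCCCCCCCCCCCCC1(C(=O)OC)CO1` has not been measured; it differs from compound 1 by hydrogen in place of 1,2-dihydroxyethyl on a saturated chain carbon bound to an oxygen next to a carbonyl group. Among the compounds with values here, no measured pair shows this change on its own, so its size is unknown. Because compound 2 with its methoxycarbonyl group gives 10 mg/kg, the step of a 2.0-fold higher number from compound 1 to compound 3 (0.30 log units; within the scatter) is expected to be small and upward, inside the scatter. Compound 3 is therefore estimated at 10 mg/kg, ranging from 3 mg/kg to 30 mg/kg.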

Compound 3, minimum effective dose: 4 mg/kg
Compound 3: middle estimate off by 2.5-fold (0.40 log units), on the high side, and the stated range covers the measured number.
By their numbers in this assay, from the lowest: compounds 3, 1 and 2 (each within the scatter of the next, the first and the last beyond it).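

In this assay, replacing 2,3-dihydroxypropoxy with methoxy gives a 1.3-fold lower number from compound 1 to compound 3 (0.10 log units; within the scatter), so at this position the diol-bearing ester and the simple methyl ester cannot be told apart. Removing octyl from the chain has a clearer outcome, with a 2.5-fold lower number from compound 2 to compound 3 (0.40 log units; beyond the scatter), a modest step beyond the scatter. Nothing available here gives a reason for either step. The compounds shown leave open how a carboxylic acid or an amide would read in place of the ester, and whether a chain shorter than that of compound 3 would shift the dose further.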